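This account rests on a few compounds, and the source may have more. Where it says the series, first, only, none or still open, it means among the compounds named here.

In a functional assay on the whole organism with Mus musculus as the target (on this read-out lower numbers stand for an effect already at smaller amounts and higher numbers for an effect only at larger amounts of compound), compound 3 (`NC(=O)/C=C1\CCc2ccc(F)cc21`) gives 56 mg/kg and thus stands within the scatter of compound 1 (`CCNC(=O)/C=C1\CCc2ccc(F)cc21`) at 70 mg/kg and of compound 2 (`CCN(C)C(=O)/C=C1\CCc2ccc(F)cc21`) at 100 mg/kg on this measure. Compound 4 (`CCCNC(=O)/C=C1\CCc2ccc(F)cc21`) differs from compound 3 in one place: propyl in place of hydrogen on an amide-type nitrogen with propyl in place of hydrogen on an amide-type nitrogen. The nearest evidence comes from the measured steps on that same nitrogen: a 1.3-fold lower number from compound 1 to compound 3 (0.10 log units; within the scatter) with hydrogen in place of ethyl, a 1.8-fold lower number from compound 2 to compound 3 (0.25 log units; within the scatter) with amino in place of ethyl(methyl)amino, and a 1.4-fold higher number from compound 1 to compound 2 (0.15 log units; within the scatter) with methyl in place of hydrogen. None of these leaves the scatter, so no step beyond the scatter is expected in this assay for this change. The expected step is a 1.3-fold higher number from compound 3 to compound 4 (0.10 log units; within the scatter) by this estimate. Compound 4 is estimated at 70 mg/kg (expected range 35 mg/kg to 140 mg/kg).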

Compound 4, dose for half-maximal effect: > 100 mg/kg
Compound 4: only a limit was reported (the forecaster's own chance of this, stated with the estimate: 5%); at least 1.4-fold (0.15 log units) between middle value and limit.
By their numbers in this assay, from the lowest: compounds 3, 1 and 2 (each within the scatter of the next).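

In this assay compound 4 gives only a limit, not a number: the limit of > 100 mg/kg in this assay, at which 1 of the 4 values shown sits. Propyl in place of hydrogen on the amide-type nitrogen gives an at least 1.7-fold higher number from compound 3 to compound 4 (0.25 log units; that floor lies within the scatter), and the shorter comparison gives an at least 1.4-fold higher number from compound 1 to compound 4 (0.15 log units; that floor lies within the scatter); both floors lie within the scatter, so neither step is shown to leave it, though the true size may be larger. The remaining comparison gives a number no lower from compound 2 to compound 4 (the limit leaves the size open), so its size cannot be read. The compounds shown leave open how large the change to propyl really is. They also leave open what a butyl chain or a carboxylic acid would give on this nitrogen.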